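This account rests on a few compounds, and the source may have more. Where it says the series, first, only, none or still open, it means among the compounds named here.

Measured so far in a functional assay on HeLa cells (Homo sapiens) for inhibition, read by sulforhodamine B assay; on this read-out lower numbers stand for stronger inhibition and higher numbers for weaker inhibition:
Compound 1, `O=C1C(NC2CCCC2)=CC(=O)c2c1nc1n2[C@H]2OC[C@@H](O)[C@H]2OC1`, gives > 16000 nM, a limit of the assay.
Compound 2, `CCc1ccc(NC2=CC(=O)c3c(nc4n3[C@H]3OC[C@@H](O)[C@H]3OC4)C2=O)cc1`, gives 6510 nM.
Compound 3, `O=C1C(NC2CC2)=CC(=O)c2c1nc1n2[C@H]2OC[C@@H](O)[C@H]2OC1`, gives > 16000 nM, again a limit of the assay.

Compound 3 thus stands at the limit of this assay, not at a number; (the limit of > 16000 nM in this assay, at which 2 of the 3 values shown sit). Compound 4, `O=C1C(Nc2cccc(F)c2)=CC(=O)c2c1nc1n2[C@H]2OC[C@@H](O)[C@H]2OC1`, has not yet been measured. It differs from compound 3 by 3-fluorophenyl in place of cyclopropyl on an amine nitrogen.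

Within the data shown here, two measured steps bear on this change. Replacing cyclopentyl by 4-ethylphenyl gave an at least 2.4-fold lower number from compound 1 to compound 2 (0.39 log units; beyond the scatter), and returning from 4-ethylphenyl to cyclopropyl gave an at least 2.4-fold higher number from compound 2 to compound 3 (0.39 log units; beyond the scatter). The step between the two cycloalkyl groups, a step that the two limits leave unreadable from compound 1 to compound 3, cannot be read. Among the measured compounds, the aryl group on the amine nitrogen sits on the lower side of either small cycloalkyl, so the move from compound 3 to compound 4 is expected to run counter to the move from compound 2 to compound 3 and to reach a number rather than a limit. Whether 3-fluorophenyl matches 4-ethylphenyl is not known from these compounds; the expected step is an at least 2.2-fold lower number from compound 3 to compound 4 (0.35 log units; beyond the scatter). For compound 4 the estimate in this assay is 7000 nM, between 2500 nM and 16000 nM.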

Compound 4, half-maximal inhibitory concentration: > 8000 nM
Compound 4: a limit, no number; the forecaster's own chance of this, stated with the estimate: 30%; middle value at least 1.1-fold (0.05 log units) from the limit.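

In this assay compound 4 gives > 8000 nM, which is a limit of the assay and not a number: the limit of > 8000 nM in this assay, at which 1 of the 4 values shown sits. An aryl group on the amine nitrogen is therefore not enough on its own to give a number in this small set: 4-ethylphenyl in compound 2 does, whereas 3-fluorophenyl in compound 4 does not, so the contrast between 4-ethylphenyl and the cycloalkyl groups does not extend to every aryl group. Among these compounds, the one readable new step is an at least 1.2-fold higher number from compound 2 to compound 4 (0.08 log units; that floor lies within the scatter), so no order can be stated for the two aryl groups, and the steps to compound 4 from compound 1 and from compound 3 cannot be read.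

The compounds shown leave open whether the number seen for compound 2 depends on the ethyl group, on the aryl ring itself, or on the ring's substitution pattern. Plain phenyl, 4-fluorophenyl and 3-ethylphenyl on the amine nitrogen would each separate these possibilities, and a longer chain such as 4-butylphenyl would show whether the trend continues beyond 4-ethylphenyl.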